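The source may report more compounds than this note shows. Statements on the series, on what has been measured and on what is new or still open speak of the compounds shown alone.

Compound 1 `CCC1C(=O)N(C)c2cnc(-n3ccc4cc(F)ccc43)nc2N1c1ccn(C)n1` has no single number to its name: in a functional assay on A549 cells (Homo sapiens) for antiproliferative activity, read by CCK-8 assay, with a stated time of 72 h (on this read-out lower numbers stand for stronger inhibition of growth and higher numbers for weaker inhibition of growth), compound 1 is recorded as "not active" (no number reported) with no figure attached. The only figure so far belongs to compound 2 `CC[C@@H]1C(=O)N(C)c2cnc(Nc3ccc(S(=O)(=O)NC4CCCC4)cc3)nc2N1C1CCCC1`, which carries different groups on the shared core, and compound 2 stands at 1150 nM in this assay as the sole anchor for the scale. Compound 3 `CCC1C(=O)N(C)c2cnc(-n3ccc4cc(C(=O)NCC(C)C)ccc43)nc2N1c1ccn(C)n1` keeps the core of compound 1 and differs in one place: isobutylcarbamoyl in place of fluoro on an aromatic carbon with isobutylcarbamoyl in place of fluoro on an aromatic carbon. For the measured compounds named here, no measured step bears on this change, and compound 1 offers no starting figure, so any size is tentative. A modest move towards stronger inhibition of growth is expected, with a real chance of no number again. Compound 3 is estimated at 2500 nM with an expected range from 400 nM to 15000 nM on present evidence.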

Compound 3, concentration for 50% growth inhibition: 19200 nM
Beside the measured number, compound 3's estimate is 7.7-fold (0.89 log units) below it; the whole stated range lies below it.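

In this assay, for the compounds shown here, compound 1 is recorded as "not active" (no number reported) and compound 3 gives 19200 nM so no step between compound 1 and compound 3 can be read. The size of any effect of exchanging fluoro for isobutylcarbamoyl stays open on the compounds shown. No evidence on hand bears on this result.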